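The source may report more compounds than this note shows. Statements on the series, on what has been measured and on what is new or still open speak of the compounds shown alone.

Measured compounds in a functional assay on SK-OV-3 cells (Homo sapiens) for cytotoxicity; a lower number here means a stronger inhibitor, a higher number a weaker inhibitor:
compound 1 `O=C(CCCCCCc1nc2ccccc2[nH]1)NO` gives 2700 nM
compound 2 `O=C(CCCCCCc1nc2ccc(-c3ccc(F)cc3)cc2[nH]1)NO` gives 1200 nM
compound 3 `CN(C)c1ccc(-c2ccc3nc(CCCCCCC(=O)NO)[nH]c3c2)cc1` gives 6600 nM

Compound 3 stands at the highest number of the three in this assay; the step of a 2.4-fold higher number from compound 1 to compound 3 (0.39 log units; beyond the scatter) and the step of a 5.5-fold higher number from compound 2 to compound 3 (0.74 log units; beyond the scatter) both place it above the other two. Compound 4 `COc1ccc2nc(CCCCCCC(=O)NO)[nH]c2c1` differs from compound 3 by methoxy in place of 4-(dimethylamino)phenyl on an aromatic carbon. Within the data shown here, the steps that bear on this are a 2.4-fold higher number from compound 1 to compound 3 (0.39 log units; beyond the scatter), where adding the 4-(dimethylamino)phenyl group to the core raised the number, and a 2.3-fold lower number from compound 1 to compound 2 (0.35 log units; beyond the scatter), where the 4-fluorophenyl group lowered it. Taking the 4-(dimethylamino)phenyl group off should undo the rise seen in a 2.4-fold higher number from compound 1 to compound 3 (0.39 log units; beyond the scatter) and bring the number back toward compound 1. Among the measured compounds shown here, no measured compound carries a methoxy group, so its own contribution is unknown; the expectation is a modest drop in this assay from compound 3, estimated as a 2.6-fold lower number from compound 3 to compound 4 (0.42 log units; beyond the scatter). Compound 4 is therefore expected to give about 2500 nM in this assay, with a range of 1000 nM to 6000 nM.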

Compound 4, half-maximal inhibitory concentration: 11000 nM
Beside the measured number, compound 4's estimate is 4.4-fold (0.64 log units) below it; the whole stated range lies below it.
By their numbers in this assay, from the lowest: compound 2; then compound 1; then compounds 3 and 4 (each within the scatter of the next).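

In this assay, methoxy in place of hydrogen on this aromatic carbon gives a 4.1-fold higher number from compound 1 to compound 4 (0.61 log units; beyond the scatter), so a rise in the number at this position does not require a ring in the substituent, as it might have seemed from compound 3 alone. Among these compounds, replacing 4-(dimethylamino)phenyl with methoxy gives a 1.7-fold higher number from compound 3 to compound 4 (0.22 log units; within the scatter), so the two groups cannot be told apart here, whereas methoxy in place of 4-fluorophenyl gives a 9.2-fold higher number from compound 2 to compound 4 (0.96 log units; beyond the scatter), leaving compound 2 as the only one of the substituted compounds with a number below that of compound 1. Nothing available accounts for these differences.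

On these data alone, it remains open whether the lower number of compound 2 depends on the fluoro group or on the phenyl ring, which unsubstituted phenyl would separate. Whether a lone fluoro or chloro on this carbon also lowers the number, or raises it as methoxy does, is equally unsettled.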